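The source may report more compounds than this note shows. Statements on the series, on what has been measured and on what is new or still open speak of the compounds shown alone.

Measured so far in a functional assay on A549 cells (Homo sapiens) for antiproliferative activity, read by MTT assay, with a stated time of 72 h; a higher number here means a weaker inhibitor, a lower number a stronger inhibitor:
- Compound 1 `COc1cc(-n2cnc3ccc(-c4ccc(C)cc4F)cc32)cc(OC)c1OC`: > 10000 nM, a limit of the assay and not a number.
- Compound 2 `COc1cc(-n2cnc3ccc(-c4ccc(C(F)(F)F)cc4)cc32)cc(OC)c1OC`: 3390 nM.

For the measured compounds named here, compound 2 gives 3390 nM, the only true number so far. Compound 3 `COc1cc(-n2cnc3ccc(-c4cccc(O)c4)cc32)cc(OC)c1OC` is next, with 3-hydroxyphenyl in place of 4-(trifluoromethyl)phenyl on an aromatic carbon.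

Going by the values given here, one measured step bears on this change, at the same aromatic carbon. It is an at least 2.9-fold lower number from compound 1 to compound 2 (0.46 log units; beyond the scatter), and it shows that exchanging the aryl group here can shift the read-out beyond the scatter. Among the compounds with values here, that step has no true number at its compound 1 end, and no compound measured so far carries 3-hydroxyphenyl, so it gives neither a firm size nor a direction for the new change. From the compounds shown here alone, a step of similar size in either direction therefore remains open in this assay, with only a slight lean towards a lower number.

The expected change is a 1.4-fold lower number from compound 2 to compound 3 (0.13 log units; within the scatter). For compound 3 the estimate is 2500 nM, with an expected range of 500 nM to 10000 nM.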

Compound 3, half-maximal inhibitory concentration: 250 nM
Estimate against measurement, compound 3: 10-fold (1.00 log units) above, outside the stated range (below it).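

For the compounds shown here, at this aromatic carbon, 3-hydroxyphenyl in place of 4-(trifluoromethyl)phenyl gives a 14-fold lower number from compound 2 to compound 3 (1.13 log units; beyond the scatter) in this assay, so the aryl group here can move the read-out by a large margin, and this pair fixes the direction for the first time in two true numbers. Against 2-fluoro-4-methylphenyl, the same group gives an at least 40-fold lower number from compound 1 to compound 3 (1.60 log units; beyond the scatter), which places 3-hydroxyphenyl ahead of both other aryl groups shown, with each step beyond the scatter. Compound 1 stands at a limit of the assay and not a number, so its step fixes only a minimum size and the true size stays unknown: the limit of > 10000 nM in this assay, at which 1 of the 3 values shown sits.

The step from compound 2 to compound 3 exchanges both the substituent and its place on the aryl ring, and it also brings in a hydrogen-bond donor and acceptor, so the compounds shown cannot say which of these differences goes with the lower number. From the compounds shown here alone, whether the gain needs the hydroxyl at all, or holds at another ring place, stays open for groups such as 4-hydroxyphenyl, 3-methoxyphenyl or 3-aminophenyl at this carbon.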